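The source may report more compounds than this note shows. Statements on the series, on what has been measured and on what is new or still open speak of the compounds shown alone.

Among the compounds with values here, in a functional assay on MC-38 cells (Mus musculus) for antiproliferative activity, read by colorimetric assay and MTT assay (on this read-out lower numbers stand for stronger inhibition and higher numbers for weaker inhibition), compound 1 `O=S(=O)(Nc1cccc2cc[nH]c12)c1ccc(Cl)cc1` gives 7 ug/mL, the highest of the three numbers so far, which makes it the weakest of the three. Compound 2 `O=S(=O)(Nc1cccc2c(Cl)c[nH]c12)c1ccc(Cl)cc1` gives 0.28 ug/mL, and compound 3 `O=S(=O)(Nc1ccc(Cl)c2cc[nH]c12)c1ccc(Cl)cc1` gives 0.66 ug/mL. Each of these two carries one extra chloro on the core of compound 1, at a different carbon.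

Compound 4 `O=S(=O)(Nc1cc(Cl)cc2cc[nH]c12)c1ccc(Cl)cc1` has not been measured yet. It differs from compound 1 by a single change: chloro in place of hydrogen on an aromatic carbon. Within the data shown here, in words, this is chloro in place of hydrogen on an aromatic carbon, and that carbon is not the one substituted in compound 2 or in compound 3.

The same kind of exchange has been measured twice, giving a 25-fold lower number from compound 1 to compound 2 (1.40 log units; beyond the scatter) and an 11-fold lower number from compound 1 to compound 3 (1.03 log units; beyond the scatter). Both steps are large and point the same way, so a lower number is expected for compound 4 too. Among the measured compounds shown here, with only two examples, and neither at this carbon, the size cannot simply be carried over, so a somewhat smaller step seems the cautious expectation. The estimated step is a 5.8-fold lower number from compound 1 to compound 4 (0.77 log units; beyond the scatter). For compound 4 the estimated value is 1.2 ug/mL, with an expected range from 0.25 ug/mL to 6 ug/mL.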

Compound 4, half-maximal inhibitory concentration: 8.5 ug/mL
The estimate for compound 4 lay 7.1-fold (0.85 log units) below the measured number; the measured number lies above the stated range.
By their numbers in this assay, from the lowest: compound 2; then compound 3; then compounds 1 and 4 (each within the scatter of the next).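

In this assay, chloro in place of hydrogen is not a change that pays off wherever it is placed on the core of compound 1. At the carbon changed here, which is meta to a large group and para to a fused ring, the exchange gives a 1.2-fold higher number from compound 1 to compound 4 (0.08 log units; within the scatter), so chloro at this carbon shows no measurable difference from hydrogen. The same exchange at two other carbons gave a 25-fold lower number from compound 1 to compound 2 (1.40 log units; beyond the scatter) and an 11-fold lower number from compound 1 to compound 3 (1.03 log units; beyond the scatter), so the outcome depends on the carbon that carries the chloro, with compound 4 going against the pattern set by compounds 2 and 3, and nothing measured here accounts for that difference between the carbons.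

The compounds shown leave open whether another group at this same carbon, such as a methyl, a methoxy or an amine, would also match hydrogen or would behave like the chloro of compounds 2 and 3. They also leave open what a core carrying chloro at two of these carbons at once would give in this read-out.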